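Primary Amide to Isopropyl Amide: Weighing the Next Step

The source may report more compounds than this note shows. Statements on the series, on what has been measured and on what is new or still open speak of the compounds shown alone.

Compound 1, `O=C(O)/C=C/c1ccc(NCc2cccc(Oc3ccccc3)c2)cc1`, gives 145 nM in a functional assay on CHO cells for agonist activity at Free fatty acid receptor 1 (Homo sapiens); a higher number here means that more compound is needed for the effect, a lower number that less compound is needed.
Compound 2, `NC(=O)CCc1ccc(NCc2cccc(Oc3ccccc3)c2)cc1`, gives 51.3 nM.

Among the compounds with values here, compound 2 holds the lowest of the two numbers; the only measured step is a 2.8-fold lower number from compound 1 to compound 2 (0.45 log units; beyond the scatter). Compound 3, `CC(C)NC(=O)CCc1ccc(NCc2cccc(Oc3ccccc3)c2)cc1`, differs from compound 2 by isopropyl in place of hydrogen on an amide-type nitrogen. Within the data shown here, no measured step touches the amide nitrogen: the single known step, a 2.8-fold lower number from compound 1 to compound 2 (0.45 log units; beyond the scatter), alters the chain bearing the amide, not its substitution, so it offers no direct guidance. Among the measured compounds shown here, with no precedent, no step beyond the scatter is expected in this assay. Compound 3 is therefore estimated at 50 nM, within 15 nM to 170 nM. This amounts to an expected 1.0-fold lower number from compound 2 to compound 3 (0.01 log units; within the scatter).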

Compound 3, half-maximal effective concentration: 39.8 nM
Estimate against measurement, compound 3: 1.3-fold (0.10 log units) above; the range from low to high includes it.
By their numbers in this assay, from the lowest: compounds 3 and 2 (each within the scatter of the next); then compound 1.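

In this assay, within the data shown here, isopropyl in place of hydrogen on the amide-type nitrogen gives a 1.3-fold lower number from compound 2 to compound 3 (0.11 log units; within the scatter), so this nitrogen, untouched by the earlier compounds, carries the added group with no step beyond the scatter. The 2-(isopropylcarbamoyl)ethyl group also keeps a difference from the 2-carboxyethenyl group, at a 3.6-fold lower number from compound 1 to compound 3 (0.56 log units; beyond the scatter). No measured evidence bears on the reason for this result. The compounds shown leave open how a tert-butyl or benzyl group on this nitrogen would read, and whether a 2-carboxyethyl group would separate the effect of the saturated chain from that of the amide.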